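Removing the Whole Side Chain: What Compound 3 May Show

The source may hold more compounds than are shown below. What is called first, only, known or untested is meant among the compounds shown, and "the series" means these compounds.

compound 1 `NCCCCNc1cc(/C=C/c2ccccc2)nc2ccccc12` — 6600 nM
compound 2 `CCOCC(=O)NCCNc1cc(/C=C/c2ccccc2)nc2ccccc12` — 22200 nM

Going by the values given here, in an ADME assay on J774 cells (Mus musculus) for cytotoxicity, read by MTT assay, with a stated time of 48 h (a higher number here means a weaker inhibitor, a lower number a stronger inhibitor), compound 2 gives the higher of the two numbers measured so far, and its nearest neighbour is compound 1. Compound 3 `Nc1cc(/C=C/c2ccccc2)nc2ccccc12` is not yet measured. It differs from compound 2 thus: hydrogen in place of 2-(((ethoxymethyl)carbonyl)amino)ethyl on a nitrogen on an aromatic ring. Among the compounds with values here, the one measured step that bears on this is a 3.4-fold higher number from compound 1 to compound 2 (0.53 log units; beyond the scatter), in which the number rose. Resting on that step alone, and with no measured compound carrying hydrogen at this nitrogen, a move back toward compound 1 is expected, probably beyond the scatter. Compound 3 is estimated at 10000 nM, with a range from 3000 nM to 35000 nM. The expected step is a 2.2-fold lower number from compound 2 to compound 3 (0.35 log units; beyond the scatter).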

Compound 3, half-maximal inhibitory concentration: 4400 nM
Compound 3: the middle estimate sits 2.3-fold (0.36 log units) above what was measured; measured number inside the range.
By their numbers in this assay, from the lowest: compounds 3 and 1 (each within the scatter of the next); then compound 2.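

In this assay hydrogen in place of 2-(((ethoxymethyl)carbonyl)amino)ethyl on a nitrogen on an aromatic ring gives a 5.0-fold lower number from compound 2 to compound 3 (0.70 log units; beyond the scatter) and so the higher number goes with that chain, since the bare core does not share it. Hydrogen in place of 4-aminobutyl gives a 1.5-fold lower number from compound 1 to compound 3 (0.18 log units; within the scatter) and so that chain cannot be told apart from hydrogen here. No measurement at hand offers a reason for either step. Still open, from the compounds shown here alone, is what a shorter chain ending in an amine, or a chain ending in a carboxylic acid, would give on this nitrogen.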